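The source may hold more compounds than are shown below. What is called first, only, known or untested is meant among the compounds shown, and "the series" means these compounds.

Measured so far:
compound 1, `CCOC(=O)CCCCCCn1c(CC)nc(-c2ccccc2)c1-c1ccccc1`, 11 nM in an assay on H4 cells for inhibition of Fatty-acid amide hydrolase 1 (Homo sapiens); a higher number here means a weaker inhibitor, a lower number a stronger inhibitor 
compound 2, `CCOC(=O)CCCCCCn1c(C)nc(-c2ccc(F)cc2)c1-c1ccc(F)cc1`, 64 nM 
compound 3, `Cc1nc(-c2ccc(F)cc2)c(-c2ccc(F)cc2)n1CCCCCCNC(=O)Oc1ccccc1F`, 10 nM 

Among these three, compound 3 carries the lowest number, but compound 1 sits so close that the two cannot be told apart, whereas compound 2 stands clearly higher. Going by the values given here, the one single-point step recorded here is a 6.4-fold lower number from compound 2 to compound 3 (0.81 log units; beyond the scatter), which swaps the ethyl ester at the end of the chain for a carbamate bearing a 2-fluorophenoxy group. Compound 1 and compound 2 differ in more than one place, so only their two values can be set side by side.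

Compound 4, `Cc1nc(-c2ccc(F)cc2)c(-c2ccc(F)cc2)n1CCCCCCNC(=O)Oc1c(F)cccc1F`, takes compound 3 one step further: fluoro in place of hydrogen on an aromatic carbon, so the 2-fluorophenoxy group becomes a 2,6-difluorophenoxy group. Among the compounds with values here, no measured pair speaks to adding a second fluorine on this ring; the only recorded step changes a different part of the molecule. With nothing pointing one way, the expectation is a step of a 1.3-fold lower number from compound 3 to compound 4 (0.10 log units; within the scatter), within the scatter. Compound 4 is therefore estimated at 8 nM, between 3 nM and 25 nM.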

Compound 4, half-maximal inhibitory concentration: 24 nM
The estimate for compound 4 lay 3.0-fold (0.48 log units) below the measured number, and the stated range covers the measured number.
By their numbers in this assay, from the lowest: compounds 3 and 1 (each within the scatter of the next); then compound 4; then compound 2.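

In this assay, a second fluorine on the phenoxy ring of the carbamate is not neutral: the change to a 2,6-difluorophenoxy group gives a 2.4-fold higher number from compound 3 to compound 4 (0.38 log units; beyond the scatter), so this aromatic carbon responds to the swap, and the response is toward a weaker inhibitor. The carbamate with this ring still compares well with the ethyl ester, with a 2.7-fold lower number from compound 2 to compound 4 (0.43 log units; beyond the scatter), so the gain from that swap survives the added fluorine. Nothing measured here explains why the second fluorine moves the number this way.

The compounds shown leave open how this ring would behave with no fluorine at all, or with a chlorine or a methoxy group in place of the fluoro. They also leave open whether a urea could stand in for the carbamate, or whether a longer chain would change the picture.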